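The source may hold more compounds than are shown below. What is called first, only, known or untested is meant among the compounds shown, and "the series" means these compounds.

In a functional assay on MGC-803 cells (Homo sapiens) for antiproliferative activity, read by MTT assay, with a stated time of 48 h (a lower number here means a stronger inhibitor, a higher number a weaker inhibitor), two compounds have been measured so far. Compound 1 `COc1cc(N(Cc2ccc(C)cc2)C(=O)CSc2nc3ccccc3s2)cc(OC)c1OC` gives 54200 nM, while compound 2 `COc1ccc(CN(C(=O)CSc2nc3ccccc3s2)c2cc(OC)c(OC)c(OC)c2)cc1` gives 163 nM, the lower of the two numbers. Among the measured compounds shown here, the only measured step, a 330-fold lower number from compound 1 to compound 2 (2.52 log units; beyond the scatter), comes with methoxy in place of methyl on an aromatic carbon.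

The next compound is compound 3 `COc1ccc(CN(C(=O)CSc2nc3ccccc3s2)c2cc(OC)c(OC)c(OC)c2)cc1[N+](=O)[O-]`, in which nitro replaces hydrogen on an aromatic carbon, ortho to a methoxy group and meta to a large group: nitro in place of hydrogen on an aromatic carbon. The 4-methoxybenzyl thus becomes 4-methoxy-3-nitrobenzyl. For the measured compounds named here, no measured step adds a group at this place, so the earlier step bears on the change only indirectly. Even so, a 330-fold lower number from compound 1 to compound 2 (2.52 log units; beyond the scatter) shows that one substituent change on this ring can move the number in this assay far beyond the scatter. Nothing measured fixes the direction of the new step, but a moderate rise is expected from the low number of compound 2, 163 nM. The expected change is a 3.1-fold higher number from compound 2 to compound 3 (0.49 log units; beyond the scatter), with wide uncertainty. For compound 3 the estimated value is 500 nM, with an expected range from 60 nM to 5000 nM.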

Compound 3, half-maximal inhibitory concentration: 682 nM
Compound 3: middle estimate off by 1.4-fold (0.13 log units), on the low side; measured number inside the range.
By their numbers in this assay, from the lowest: compound 2; then compound 3; then compound 1.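

In this assay, among the compounds shown here, this is the first look at adding a group to the benzyl ring rather than exchanging one: nitro in place of hydrogen, ortho to a methoxy group, gives a 4.2-fold higher number from compound 2 to compound 3 (0.62 log units; beyond the scatter), a modest step that lies beyond the scatter and leaves the 4-methoxybenzyl of compound 2 the better of the two at this ring. The ring therefore accepts an added nitro with a far smaller penalty than the earlier swap of methoxy for methyl suggested a single change could bring, and the 4-methoxy-3-nitrobenzyl still keeps most of the gain over the methyl-bearing ring, as a 79-fold lower number from compound 1 to compound 3 (1.90 log units; beyond the scatter) shows, a large step. No measured evidence here explains why the nitro group costs this much or why the ring tolerates it.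

The compounds shown leave open whether an amine, a fluorine or a carboxylic acid at the same place would stay as close to compound 2 as the nitro does, or would move the number further. They also leave open how a nitro group would behave on the 4-methylbenzyl ring of compound 1, or with a hydroxy group in place of the methoxy beside which it sits.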